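Two Limits and a Difluorobenzyl Amide Awaiting Its Number

The source may hold more compounds than are shown below. What is called first, only, known or untested is meant among the compounds shown, and "the series" means these compounds.

The account opens with compound 1, `COc1cccc(NC(=O)/C=C/c2coc3cc(OC)ccc3c2=O)c1`, a chromone acrylamide that was tested in a functional assay on L02 cells (Homo sapiens) for inhibition, read by MTT assay, with a stated time of 48 h; a higher number here means a weaker inhibitor, a lower number a stronger inhibitor. In this assay compound 1 reaches only a limit, giving > 200000 nM, so no number is known for it. Its companion compound 2, `O=C(/C=C/c1coc2cc(O)ccc2c1=O)Nc1ccccc1`, carries a free hydroxyl on the shared core. In this assay compound 2 likewise stops at a limit, giving > 200000 nM. Both values therefore sit at the limit of > 200000 nM in this assay, at which 2 of the 2 values shown sit, and compound 1 stands at the same limit as the only other compound shown, with no measured step between the two.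

The unmeasured compound is compound 3, `COc1ccc2c(=O)c(/C=C/C(=O)NCc3ccc(F)cc3F)coc2c1`. It differs from compound 1 by 2,4-difluorobenzyl in place of 3-methoxyphenyl on an amide-type nitrogen, and the shared core is untouched.

For the measured compounds named here, with no measured step to lean on, the expectation rests on the two limits alone. The step of a number no higher from compound 1 to compound 3 (the limit leaves the size open) is expected to be none beyond the scatter, with a fair chance that this assay again reports only a limit. Compound 3 is accordingly estimated at 200000 nM, within 100000 nM to 400000 nM.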

Compound 3, half-maximal inhibitory concentration: > 200000 nM
Compound 3 ended at the assay's limit; the forecaster's own chance of this, stated with the estimate: 80%; the middle value sits exactly at the limit.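

In this assay compound 3 gives > 200000 nM and this is a limit, not a number. For the compounds shown here, compound 1 also stands at a limit, so no step between compound 1 and compound 3 can be read: the limit of > 200000 nM in this assay, at which 3 of the 3 values shown sit. On these data alone, what stays open is whether in this assay the 2,4-difluorobenzyl and 3-methoxyphenyl groups on the amide-type nitrogen differ at all.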